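Spiro oxa-azetidine replaces hydroxypiperidine on the sulfonyl

A few compounds are considered here, and "the series" means these few. Any claim that something is new, unique, unknown or untested is made for them only; others in the source may bear on it.

Compound 2 `O=C(NCc1ccc(S(=O)(=O)N2CCC[C@H](O)C2)cc1)N1Cc2ccncc2C1` gives 770 nM in an assay on isolated protein for inhibition of Nicotinamide phosphoribosyltransferase (Homo sapiens), read by mass spectrometry, with stated times of 15 min and 30 min (on this read-out lower numbers stand for stronger inhibition and higher numbers for weaker inhibition), the higher of the two numbers shown; compound 1 `CC(=O)N1CCC(S(=O)(=O)c2ccc(CNC(=O)N3Cc4ccncc4C3)cc2)CC1` gives 83 nM in this assay. Compound 3 `O=C(NCc1ccc(S(=O)(=O)N2CC3(CCOCC3)C2)cc1)N1Cc2ccncc2C1` carries a group of 9 heavy atoms (7 carbon, 1 nitrogen, 1 oxygen; one four-membered non-aromatic ring with 1 hetero atom, one six-membered non-aromatic ring with 1 hetero atom) in place of a group of 7 heavy atoms (5 carbon, 1 nitrogen, 1 oxygen; one six-membered non-aromatic ring with 1 hetero atom), on a sulfonyl sulfur. Among the compounds with values here, the only measured step, a 9.3-fold higher number from compound 1 to compound 2 (0.97 log units; beyond the scatter), shows that exchanging the group on this sulfonyl sulfur can move the number well beyond the scatter, but it does not involve the group entering in compound 3, so its direction is uncertain. For compound 3 the expected step is a 1.5-fold lower number from compound 2 to compound 3 (0.19 log units; within the scatter), with an estimated value of 500 nM and a range from 120 nM to 2000 nM.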

Compound 3, half-maximal inhibitory concentration: 20 nM
Beside the measured number, compound 3's estimate is 25-fold (1.40 log units) above it; the measured number lies below the stated range.
By their numbers in this assay, from the lowest: compound 3; then compound 1; then compound 2.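

In this assay, a 39-fold lower number from compound 2 to compound 3 (1.59 log units; beyond the scatter) shows that the group with a four-membered and a six-membered ring on the sulfonyl sulfur gives a much lower number than 3-hydroxypiperidin-1-yl, a larger change at this position than the earlier step showed. It also surpasses the 1-acetylpiperidin-4-yl group, with a 4.2-fold lower number from compound 1 to compound 3 (0.62 log units; beyond the scatter), making compound 3 the most potent of the three. No evidence bears on why this exchange has such an effect. Still open, on these data alone, is which ring accounts for the gain, and whether a simple azetidine or a morpholine on the sulfonyl sulfur would give a similar number.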